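Chlorine Added to a Cyclopropyl Amide: Expected Toxicity

The source may hold more compounds than are shown below. What is called first, only, known or untested is meant among the compounds shown, and "the series" means these compounds.

Of the compounds shown here, three have been measured in a toxicity assay on the whole organism (strain Icem-CET (SPF Caw)) for cytotoxicity, with Mus musculus as the target; on this read-out lower numbers stand for an effect already at smaller amounts and higher numbers for an effect only at larger amounts of compound. Compound 3 `C#CCNC(=O)/C(C)=C(\C)c1ccccc1` gives 150 mg/kg. Compound 1 `C#CCNC(=O)/C(C)=C(\C)c1ccc(Cl)cc1` differs from compound 3 by a single change (chloro in place of hydrogen on an aromatic carbon), and in this assay compound 1 gives 60 mg/kg, a step of a 2.5-fold lower number from compound 3 to compound 1 (0.40 log units; beyond the scatter). Compound 2 `C/C(C(=O)NC1CC1)=C(\C)c1ccccc1` carries a different core; how the cores of compound 2 and compound 3 differ is not broken down here. In this assay compound 2 gives 400 mg/kg, the highest of the three numbers. Compound 4 `C/C(C(=O)NC1CC1)=C(\C)c1ccc(Cl)cc1` is not yet measured and differs from compound 2 by the same change (chloro in place of hydrogen on an aromatic carbon), at the same place as before. Since the earlier step of a 2.5-fold lower number from compound 3 to compound 1 (0.40 log units; beyond the scatter) lay beyond the scatter, a step of similar size is expected here, estimated as a 2.5-fold lower number from compound 2 to compound 4 (0.40 log units; beyond the scatter). Compound 4 is therefore expected to give about 160 mg/kg in this assay, probably between 80 mg/kg and 320 mg/kg.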

Compound 4, dose for half-maximal effect: 170 mg/kg
The estimate for compound 4 lay 1.1-fold (0.03 log units) below the measured number, and the stated range covers the measured number.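

In this assay, chloro in place of hydrogen on an aromatic carbon again lowers the number, with a 2.4-fold lower number from compound 2 to compound 4 (0.37 log units; beyond the scatter). The change therefore carries from one core to the other with much the same size: the same change on two cores in this assay, a 2.5-fold lower number (0.40 log units; beyond the scatter) from compound 3 to compound 1 and a 2.4-fold lower number (0.37 log units; beyond the scatter) from compound 2 to compound 4, 1.1-fold (0.03 log units) apart, within the scatter of two such steps. Among the compounds shown here, this rests on only two pairs of compounds in one assay, so it does not show why the number falls or that the step would hold on other cores.

The compounds shown leave open whether fluoro, bromo or methoxy at the same place would give a step of similar size. They also leave open how a longer chain on the amide would compare with the groups there now.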